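Swapping the acyl group of compound 2 for a sulfonyl group

The source may report more compounds than this note shows. Statements on the series, on what has been measured and on what is new or still open speak of the compounds shown alone.

Measured in a physicochemical assay for solubility; on this read-out lower numbers stand for lower solubility and higher numbers for higher solubility:
- compound 1 `CN(C)c1ccc(C(=O)N2CCC(NS(=O)(=O)c3cc(S(=O)(=O)c4ccccc4)ccc3C(F)(F)F)CC2)cc1`: 50000 nM
- compound 2 `O=C(c1ccccn1)N1CCC(NS(=O)(=O)c2cc(S(=O)(=O)c3ccccc3)ccc2C(F)(F)F)CC1`: 100000 nM
- compound 3 `CN(C)c1ccc(C(=O)N2CCC(NS(=O)(=O)c3cc(S(=O)(=O)c4ccccc4)ccc3C(F)(F)F)CC2)cn1`: 12500 nM

Compound 2 and compound 1 cannot be told apart, with a 2.0-fold higher number from compound 1 to compound 2 (0.30 log units; within the scatter). Together they stand clear of compound 3, as an 8.0-fold lower number from compound 2 to compound 3 (0.90 log units; beyond the scatter) and a 4.0-fold lower number from compound 1 to compound 3 (0.60 log units; beyond the scatter) both show.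

The next compound to be read in this assay is compound 4 `O=C(O)c1cccc(S(=O)(=O)N2CCC(NS(=O)(=O)c3cc(S(=O)(=O)c4ccccc4)ccc3C(F)(F)F)CC2)c1`, which differs from compound 2 in one place: (3-carboxyphenyl)sulfonyl in place of (pyridin-2-yl)carbonyl on an amine nitrogen in a ring. It carries (3-carboxyphenyl)sulfonyl in place of (pyridin-2-yl)carbonyl on an amine nitrogen in a ring.

The measured steps bear on this only loosely. Among the measured compounds shown here, each of them swaps the group on a carbonyl carbon and keeps the carbonyl, and no measured compound has a sulfonyl at this place or a (3-carboxyphenyl) group. They range from within the scatter, in a 2.0-fold higher number from compound 1 to compound 2 (0.30 log units; within the scatter), to modest, in an 8.0-fold lower number from compound 2 to compound 3 (0.90 log units; beyond the scatter). They give no direction for the new change, so no step beyond the scatter is expected, though the uncertainty is wide. The expected step is no change at the digits printed from compound 2 to compound 4 (within the scatter). Compound 4 is estimated at 100000 nM, with an expected range of 25000 nM to 250000 nM.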

Compound 4, solubility: 12500 nM
For compound 4 the middle estimate is 8.0-fold (0.90 log units) above the measured one; the whole stated range lies above it.
By their numbers in this assay, from the lowest: compounds 3 and 4 (each within the scatter of the next); then compounds 1 and 2 (each within the scatter of the next).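

Working notes on the series: in this assay, a sulfonyl-linked group on the amine nitrogen in a ring gives a read-out clearly separated from the two higher acyl compounds, with an 8.0-fold lower number from compound 2 to compound 4 (0.90 log units; beyond the scatter) and a 4.0-fold lower number from compound 1 to compound 4 (0.60 log units; beyond the scatter). Against the remaining acyl compound there is no change at the digits printed from compound 3 to compound 4 (within the scatter), so (3-carboxyphenyl)sulfonyl and (6-(dimethylamino)pyridin-3-yl)carbonyl cannot be told apart at this place, and the change from carbonyl to sulfonyl does not by itself take the series outside the range already spanned by the acyl compounds. No measurement at hand bears on the reason for these steps.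

In the compounds shown, the sulfonyl link and the carboxylic acid arrive together, so the steps cannot be divided between them. A (pyridin-2-yl)sulfonyl group and a (3-carboxyphenyl)carbonyl group on the same nitrogen would separate the two changes, and a plain phenylsulfonyl group would show the read-out of the sulfonyl link without the carboxylic acid.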